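The compounds below may be only part of what the source reports. "The series", "measured", "known", "first", "only" and "open" are said of these compounds alone.

The two compounds with a result so far:

compound 1, `COc1cccc(Oc2ccc3c(NCCCNCc4cc(F)ccc4OC)ccnc3c2)c1` — 7100 nM
compound 2, `COc1ccc(-c2ccc3c(NCCCNCc4ccco4)ccnc3c2)cc1` — 6000 nM

Both were tested in an ADME assay on HepG2 cells (Homo sapiens) for cytotoxicity, read by luminescence, CellTiter-Glo and ATP content, with a stated time of 72 h; a higher number here means that more compound is needed for the effect, a lower number that less compound is needed. In this assay compound 1 gives 7100 nM, the higher of the two numbers, while compound 2 gives 6000 nM. The gap between them lies within the usual scatter of repeated measurements, so the two cannot be told apart on these numbers; compound 1 simply sits at the top of a very narrow pair.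

Compound 3, `COc1ccc(F)cc1CNCCCNc1ccnc2cc(-c3cccc4ccccc34)ccc12`, has not yet been measured. It differs from compound 1 in one place:

naphthalen-1-yl in place of 3-methoxyphenoxy on an aromatic carbon

Among the compounds with values here, with no pair of measured compounds differing in a single place, there is no measured step to lean on. The step from compound 1 to compound 3 is expected to be small, most likely a modest move toward a lower number, and quite possibly not beyond the scatter: a 1.8-fold lower number from compound 1 to compound 3 (0.25 log units; within the scatter) is the expected change. On that basis compound 3 is estimated at 4000 nM in this assay, within a range of 1500 nM to 12000 nM.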

Compound 3, half-maximal effective concentration: 16000 nM
Beside the measured number, compound 3's estimate is 4.0-fold (0.60 log units) below it; the measured number lies above the stated range.
By their numbers in this assay, from the lowest: compounds 2 and 1 (each within the scatter of the next); then compound 3.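

In this assay, within the data shown here, putting naphthalen-1-yl in place of 3-methoxyphenoxy gives a 2.3-fold higher number from compound 1 to compound 3 (0.35 log units; beyond the scatter) and so provides the first single-place comparison in this set. It shows that this aromatic carbon is not indifferent to the group it carries: the step is modest, but it lies beyond the scatter, and more compound is needed for the effect. The swap alters several features at once, since two oxygen atoms and both hydrogen-bond acceptors leave while a second six-membered aromatic ring enters, and no measurement shown here accounts for the shift.

As far as these compounds go, what remains open is which of these features matters, as this one step cannot separate the loss of the oxygen atoms from the gain of the second ring. A plain phenyl group, a plain phenoxy group or a pyridin-3-yl ring at the same carbon would help to pull those features apart, and repeating the same swap with a different amine side chain would test whether the step holds beyond this one pair.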